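The source may hold more compounds than are shown below. What is called first, only, known or untested is meant among the compounds shown, and "the series" means these compounds.

Measured in a functional assay on HL-60 cells (Homo sapiens) for cytotoxicity, read by WST assay, with a stated time of 48 h; a lower number here means a stronger inhibitor, a higher number a weaker inhibitor:
- compound 1 `COc1cc(C(c2ccc(O)c(OC)c2)[C@H](CF)C(C)C)ccc1O` gives 19000 nM
- compound 2 `CCCCC[C@H](C(C)C)C(c1ccc(O)c(OC)c1)c1ccc(O)c(OC)c1` gives 9600 nM
- compound 3 `COc1cc(C(c2ccc(O)c(OC)c2)[C@H](C)[C@@H](C)CF)ccc1O` gives 45000 nM

Compound 3 has the highest number of the three, which makes it the weakest so far. Compound 4 `COc1cc(C(c2ccc(O)c(OC)c2)[C@@H](CF)C(C)C)ccc1O` changes one group on a saturated chain carbon bound to two aromatic carbons: 1-(fluoromethyl)-2-methylpropyl in place of 2-(fluoromethyl)-1-methylpropyl on a saturated chain carbon bound to two aromatic carbons. The closest evidence is the same pair of groups swapped the other way, a 2.4-fold higher number from compound 1 to compound 3 (0.37 log units; beyond the scatter), a modest step. The other step, a 4.7-fold higher number from compound 2 to compound 3 (0.67 log units; beyond the scatter), is larger but starts from a different group, so it bears less on this change. Reversing the closest step, a modest move to a lower number is expected in this assay. The expected step is a 2.0-fold lower number from compound 3 to compound 4 (0.31 log units; beyond the scatter). Compound 4 is estimated at 22000 nM, with an expected range from 10000 nM to 45000 nM.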

Compound 4, half-maximal inhibitory concentration: 39000 nM
The estimate for compound 4 lay 1.8-fold (0.25 log units) below the measured number; measured number inside the range.
By their numbers in this assay, from the lowest: compounds 2 and 1 (each within the scatter of the next); then compounds 4 and 3 (each within the scatter of the next).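

In this assay, the change of group on this carbon can leave the number unmoved, with a 1.2-fold lower number from compound 3 to compound 4 (0.06 log units; within the scatter). Configuration alone moves the number, with a 2.1-fold higher number from compound 1 to compound 4 (0.31 log units; beyond the scatter), and the cause this pair points to is the drawn stereocentre: the fact that compounds 1 and 4 differ only in the configuration as drawn. The 1-isopropylhexyl group keeps the lower number against 1-(fluoromethyl)-2-methylpropyl, with a 4.1-fold higher number from compound 2 to compound 4 (0.61 log units; beyond the scatter). Going by these compounds, whether configuration at this stereocentre matters in the same way with other groups, such as 1-isopropylhexyl or a chain ending in an amine, stays open.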